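A few compounds are considered here, and "the series" means these few. Any claim that something is new, unique, unknown or untested is made for them only; others in the source may bear on it.

Measured set:
compound 1 `O=C(CSc1nnc(-c2ccncc2)o1)N/N=C/c1ccc(Br)cc1`: 18600 nM in a functional assay on HepG2 cells (Homo sapiens) for cytotoxicity, read by MTT assay, with a stated time of 48 h; on this read-out higher numbers stand for weaker inhibition and lower numbers for stronger inhibition
compound 2 `O=C(CSc1nnc(-c2ccncc2)o1)N/N=C/c1ccccc1O`: 3510 nM
compound 3 `O=C(CSc1nnc(-c2ccncc2)o1)N/N=C/c1cc(Cl)cc(Cl)c1O`: 3260 nM

Compound 1 stands highest of the three numbers. Its nearest neighbour is compound 2, a 5.3-fold lower number from compound 1 to compound 2 (0.72 log units; beyond the scatter), and its furthest is compound 3, a 5.7-fold lower number from compound 1 to compound 3 (0.76 log units; beyond the scatter). Compound 2 and compound 3 sit together, a 1.1-fold lower number from compound 2 to compound 3 (0.03 log units; within the scatter).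

Compound 4 `O=C(CSc1nnc(-c2ccncc2)o1)N/N=C/C=C/c1ccccc1` differs from compound 1 in one place: 2-phenylethenyl in place of 4-bromophenyl on a carbon with a double bond to nitrogen. Going by the values given here, the only steps on record start from compound 1 and replace the same 4-bromophenyl, a 5.3-fold lower number from compound 1 to compound 2 (0.72 log units; beyond the scatter) and a 5.7-fold lower number from compound 1 to compound 3 (0.76 log units; beyond the scatter), both modest and in the same direction. Among the compounds with values here, both entering groups there carried a hydroxyl, which 2-phenylethenyl does not; no measured step exchanges the 4-bromophenyl for a group without donors or acceptors. Those two steps therefore bear only loosely on this one. The expectation is a step in the same lowering direction but smaller, perhaps not beyond the scatter, a 1.9-fold lower number from compound 1 to compound 4 (0.27 log units; within the scatter). Compound 4 is estimated at 10000 nM, with a range from 4000 nM to 28000 nM.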

Compound 4, half-maximal inhibitory concentration: 7420 nM
Beside the measured number, compound 4's estimate is 1.3-fold (0.13 log units) above it; measured number inside the range.
By their numbers in this assay, from the lowest: compounds 3 and 2 (each within the scatter of the next); then compound 4; then compound 1.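

In this assay, the lowering at this carbon with a double bond to nitrogen does not depend on a hydroxyl in the entering group: 2-phenylethenyl also gives a lower number than 4-bromophenyl (a 2.5-fold lower number from compound 1 to compound 4 (0.40 log units; beyond the scatter)). The hydroxyl-bearing groups still give lower numbers than 2-phenylethenyl (a 2.1-fold higher number from compound 2 to compound 4 (0.33 log units; beyond the scatter); a 2.3-fold higher number from compound 3 to compound 4 (0.36 log units; beyond the scatter)), so compound 4 sits apart from both compound 2 and compound 3 as well as from compound 1. No measured evidence explains these differences.

Compound 4 loses the bromine and gains a double bond outside aromatic rings in the same change, and an unsubstituted phenyl would be needed to separate the two. Going by these compounds, whether an amine in place of the hydroxyl on the phenyl ring would match compound 2 also remains open.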